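Positional isomer of the dimethylphenyl group on the triazole

The source may report more compounds than this note shows. Statements on the series, on what has been measured and on what is new or still open speak of the compounds shown alone.

Measured compounds in a functional assay on HCT-116 cells (Homo sapiens) for antiproliferative activity, read by MTT assay, with a stated time of 48 h; a higher number here means a weaker inhibitor, a lower number a stronger inhibitor:
compound 1 `N#CC1=C(N)Oc2c(N)cc3nc4ccccc4nc3c2C12C(=O)N(Cc1cnnn1-c1ccccc1Br)c1ccccc12`: 12400 nM
compound 2 `N#CC1=C(N)Oc2c(N)cc3nc4ccccc4nc3c2C12C(=O)N(Cc1cnnn1-c1ccc([N+](=O)[O-])cc1)c1ccccc12`: > 50000 nM
compound 3 `Cc1ccc(-n2nncc2CN2C(=O)C3(C(C#N)=C(N)Oc4c(N)cc5nc6ccccc6nc5c43)c3ccccc32)cc1C`: > 50000 nM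

Compound 3 stands at a limit: in this assay compound 3 gives only > 50000 nM, a limit of the assay and not a number. Compound 2 likewise gives only a limit, > 50000 nM. Going by the values given here, compound 1 is the one compound with a number, 12400 nM, and it carries the 2-bromophenyl group.

Compound 4 `Cc1ccc(C)c(-n2nncc2CN2C(=O)C3(C(C#N)=C(N)Oc4c(N)cc5nc6ccccc6nc5c43)c3ccccc32)c1` differs from compound 3 in one place: 2,5-dimethylphenyl in place of 3,4-dimethylphenyl on an aromatic nitrogen.

Among the compounds with values here, none of the measured steps changes one dimethylphenyl for another. The steps of an at least 4.0-fold higher number from compound 1 to compound 3 (0.60 log units; beyond the scatter) and an at least 4.0-fold higher number from compound 1 to compound 2 (0.60 log units; beyond the scatter) show that both the 3,4-dimethylphenyl and the 4-nitrophenyl groups weaken activity relative to the 2-bromophenyl group, and the step that the two limits leave unreadable from compound 2 to compound 3 cannot be read because of the limit of > 50000 nM in this assay, at which 2 of the 3 values shown sit. Within the data shown here, the move from 3,4-dimethylphenyl to 2,5-dimethylphenyl has no measured counterpart, so the expected step of an at least 1.4-fold lower number from compound 3 to compound 4 (0.15 log units; that floor lies within the scatter) is uncertain and could be none beyond the scatter. The estimate for compound 4 is therefore 35000 nM, between 10000 nM and 80000 nM, with a fair chance that only a limit is again reported.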

Compound 4, half-maximal inhibitory concentration: > 50000 nM
Compound 4: only a limit was reported; the forecaster's own chance of this, stated with the estimate: 45%; middle value at least 1.4-fold (0.15 log units) from the limit.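

Moving the methyl groups from the 3,4-dimethylphenyl to the 2,5-dimethylphenyl arrangement brings no readable gain in this assay: compound 4 also ends at a limit of the assay and not at a number. Replacing the 2-bromophenyl group of compound 1 with 2,5-dimethylphenyl gives an at least 4.0-fold higher number from compound 1 to compound 4 (0.60 log units; beyond the scatter), so a group at the 2 position of this phenyl ring does not by itself keep a measurable value, and compound 1 remains the only one of the four with a number. The steps from compound 2 and from compound 3 to compound 4 cannot be read, because all three compounds stop at the same limit: the limit of > 50000 nM in this assay, at which 3 of the 4 values shown sit.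

The compounds shown leave open whether the value of compound 1 depends on bromine itself or would also appear with a 2-chlorophenyl, 2-methylphenyl or 2-methoxyphenyl group, and whether a 3-bromophenyl or 4-bromophenyl group would give a number at all. As far as these compounds go, how compound 2, compound 3 and compound 4 rank against one another also stays unknown.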